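This account rests on a few compounds, and the source may have more. Where it says the series, first, only, none or still open, it means among the compounds named here.

Compound 1 `CO[C@H]1CC[C@H](Nc2cc(NCc3cnccc3C(F)(F)F)ncc2C#N)CC1` gives in an assay on isolated protein for inhibition of protein kinase C delta type (Homo sapiens), read by TR-FRET, with a stated time of 2 h (on this read-out higher numbers stand for weaker inhibition and lower numbers for stronger inhibition), a value that is only a limit, > 10000 nM. Compound 2 `CO[C@H]1CC[C@@H](CNc2cc(NCc3cnccc3C(F)(F)F)ncc2C#N)CC1` gives 5000 nM. Compound 3 `CC1(C)C[C@H](Nc2cc(NCc3cnccc3C(F)(F)F)ncc2C#N)CC[C@H]1O` gives 2200 nM.

Among the measured compounds, compound 3 holds the lowest of the two genuine numbers; its nearest neighbour is compound 2, and the change runs a 2.3-fold lower number from compound 2 to compound 3 (0.36 log units; beyond the scatter). Against compound 1 the same group swap runs an at least 4.5-fold lower number from compound 1 to compound 3 (0.65 log units; beyond the scatter), though that figure rests on the limit of > 10000 nM in this assay, at which 1 of the 3 values shown sits, and is therefore only a floor. The step of an at least 2.0-fold lower number from compound 1 to compound 2 (0.30 log units; that floor lies within the scatter) is likewise bounded by that limit.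

Compound 4 `CC1(C)[C@@H](C(N)=O)C[C@H]1Nc1cc(NCc2cnccc2C(F)(F)F)ncc1C#N` differs from compound 3 by 3-carbamoyl-2,2-dimethylcyclobutyl in place of 4-hydroxy-3,3-dimethylcyclohexyl on a nitrogen on an aromatic ring. Among the measured compounds shown here, all three measured steps alter the group on this same nitrogen, and they shift this assay by modest amounts at most; none of them exchanges the ring size or replaces the hydroxyl by a carbamoyl group, so no direct precedent exists. The expected step is therefore small, a 1.1-fold higher number from compound 3 to compound 4 (0.06 log units; within the scatter), with no confident direction. Compound 4 is estimated at 2500 nM in this assay, within a range from 700 nM to 9000 nM.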

Compound 4, half-maximal inhibitory concentration: 160 nM
The estimate for compound 4 lay 16-fold (1.19 log units) above the measured number, outside the stated range (below it).
By their numbers in this assay, from the lowest: compound 4; then compound 3; then compound 2. At a limit, above all of these: compound 1.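

Among the compounds shown here, the result shows that the group on this nitrogen can shift this assay by far more than the earlier steps suggested, with large changes of a 14-fold lower number from compound 3 to compound 4 (1.14 log units; beyond the scatter) and a 31-fold lower number from compound 2 to compound 4 (1.49 log units; beyond the scatter). The first of these steps replaces 4-hydroxy-3,3-dimethylcyclohexyl with 3-carbamoyl-2,2-dimethylcyclobutyl, and the counts of heavy atoms, hydrogen-bond donors and hydrogen-bond acceptors are the same in both groups, so those counts do not separate the two compounds. The step of an at least 62-fold lower number from compound 1 to compound 4 (1.79 log units; beyond the scatter) is only a floor, as compound 1 stands at a limit: the limit of > 10000 nM in this assay, at which 1 of the 4 values shown sits.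

The four-membered ring and the carbamoyl group enter together, so the compounds shown do not tell which of them carries the large step, or whether it needs both; a 3-hydroxy-2,2-dimethylcyclobutyl group and a 4-carbamoyl-3,3-dimethylcyclohexyl group would pull the two apart. Going by these compounds, it also remains open whether a carboxylic acid, a methyl ester or an N-methyl amide in place of the carbamoyl group, or the opposite arrangement at the two defined stereocentres, would keep the number near that of compound 4.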